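Trifluoromethoxy in Place of Fluoro: An Expected Small Step

The compounds below may be only part of what the source reports. "The series", "measured", "known", "first", "only" and "open" are said of these compounds alone.

Of the compounds shown here, two have so far been tested in an assay on isolated protein for inhibition of DNA topoisomerase 1 (Homo sapiens), with a stated time of 30 min, tested at 20 uM; a higher number here means a stronger effect of the compound at the concentration tested, a lower number a weaker effect. Compound 1 `O=c1[nH]c(-c2cccc3ccccc23)nc2ccc(N3CCCCC3)cc12` gives 33.4% in this assay. Compound 2 `Cc1ccc2c(=O)[nH]c(-c3cccc(F)c3)nc2c1` gives 4.3% in this assay, the lower of the two numbers, standing below compound 1 by a gap that lies beyond the usual scatter of such measurements.

Compound 3 `Cc1ccc2c(=O)[nH]c(-c3cccc(OC(F)(F)F)c3)nc2c1` is the next compound to be tested. It differs from compound 2 in one place: trifluoromethoxy in place of fluoro on an aromatic carbon. Within the data shown here, no pair of measured compounds differs in only one place, so no measured step offers a guide to this change. The account therefore expects a step from compound 2 to compound 3 of a number 4.7 percentage points higher from compound 2 to compound 3 (within the scatter) in this assay, that is, little or no movement beyond the scatter. On that basis compound 3 is estimated to give 9% in this assay, within a range from 0% to 25%.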

Compound 3, a percentage reported as inhibition, at one concentration (the size of the read-out at that concentration, not a potency): 0%
Estimate against measurement, compound 3: 9 percentage points above; the range from low to high includes it.
By their numbers in this assay, from the lowest: compounds 3 and 2 (each within the scatter of the next); then compound 1.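

In this assay, trifluoromethoxy in place of fluoro on this aromatic carbon, meta to a large group, comes to a number 4.3 percentage points lower from compound 2 to compound 3 (within the scatter). Among these compounds, this is the first step between compounds that differ in one place, and it shows that going from one heavy atom to five at this position, with a hydrogen-bond acceptor added, does not move the read-out beyond the scatter. Nothing measured here bears on why compound 2 and compound 3 read alike.

On these data alone, whether any other group on this carbon, such as an amine or a carboxylic acid, would move the read-out remains open. As far as these compounds go, compound 2 and compound 3 differ from compound 1 in more than one place, so which of those differences goes with compound 1 at 33.4% also remains open.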